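The compounds below may be only part of what the source reports. "The series", "measured", "known", "first", "only" and "open" are said of these compounds alone.

Compounds measured in an ADME assay on NIH3T3 cells (Mus musculus) for cytotoxicity, read by MTT assay, with a stated time of 24 h; on this read-out higher numbers stand for weaker inhibition and lower numbers for stronger inhibition:
- compound 1 `O=C(CSc1nnc(-c2ccncc2)o1)N/N=C/c1ccc(Cl)cc1` — 181000 nM
- compound 2 `O=C(CSc1nnc(-c2ccncc2)o1)N/N=C/c1ccccc1[N+](=O)[O-]` — 214000 nM
- compound 3 `O=C(CSc1nnc(-c2ccncc2)o1)N/N=C/c1ccccc1O` — 155000 nM

These three share a common core and differ only in the aryl group on the carbon with a double bond to nitrogen. Compound 3 stands within the usual scatter of both its neighbours: a 1.2-fold lower number from compound 1 to compound 3 (0.07 log units; within the scatter) and a 1.4-fold lower number from compound 2 to compound 3 (0.14 log units; within the scatter), so the three numbers cannot be told apart.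

Compound 4 `O=C(CSc1nnc(-c2ccncc2)o1)N/N=C/c1cc(Cl)cc(Cl)c1O` is not yet measured; it differs from compound 3 in one place: 3,5-dichloro-2-hydroxyphenyl in place of 2-hydroxyphenyl on a carbon with a double bond to nitrogen. For the measured compounds named here, no measured step adds chlorine to the hydroxyphenyl, but two steps bear on the matter. The step of a 1.4-fold lower number from compound 2 to compound 3 (0.14 log units; within the scatter) exchanges one substituent on the aromatic carbon for another without effect beyond the scatter, and compound 1, which carries a chlorine on its phenyl, gives a value within scatter of compound 3. The changes seen so far on this aryl group, a 1.2-fold higher number from compound 1 to compound 2 (0.07 log units; within the scatter) included, have all stayed inside the scatter.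

Compound 4 is therefore expected to show no step beyond the scatter, a 1.1-fold lower number from compound 3 to compound 4 (0.04 log units; within the scatter), with an estimated value of 140000 nM in a range from 70000 nM to 280000 nM.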

Compound 4, half-maximal inhibitory concentration: 171000 nM
Estimate against measurement, compound 4: 1.2-fold (0.09 log units) below; measured number inside the range.
By their numbers in this assay, from the lowest: compounds 3, 4, 1 and 2 (each within the scatter of the next).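

In this assay, the 3,5-dichloro-2-hydroxyphenyl group, with two chlorine atoms on top of the hydroxy group, shows that even this larger aryl group on the carbon with a double bond to nitrogen leaves the number inside the scatter, with a 1.1-fold higher number from compound 3 to compound 4 (0.04 log units; within the scatter). The same holds against the other two aryl groups, with a 1.3-fold lower number from compound 2 to compound 4 (0.10 log units; within the scatter) and a 1.1-fold lower number from compound 1 to compound 4 (0.02 log units; within the scatter), so all four compounds remain indistinguishable at this position. Nothing available offers an explanation for this flat result.

The compounds shown leave open whether an amine or a carboxylic acid on the phenyl ring, or a longer alkyl chain in place of the aryl group, would move the number beyond the scatter. They also leave open whether any change to the shared core would do so.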